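The source may report more compounds than this note shows. Statements on the series, on what has been measured and on what is new or still open speak of the compounds shown alone.

In an ADME assay on Vero cells (Chlorocebus sabaeus) for cytotoxicity, read by CellTiter-Glo, with a stated time of 72 h (a lower number here means that less compound is tolerated, a higher number that more compound is tolerated), compound 1 (`CCNc1n[n+]([O-])c2ccccc2[n+]1[O-]`) gives 17 ug/mL, which lies within the scatter of compound 2 (`[O-][n+]1nc(NC2CCCC2)[n+]([O-])c2ccccc21`) at 10 ug/mL. Compound 3 (`C[C@@H](Nc1n[n+]([O-])c2ccccc2[n+]1[O-])C1CCCCC1`) differs from compound 1 by cyclohexyl in place of hydrogen on a saturated chain carbon bound to a nitrogen on an aromatic ring and a saturated chain carbon, with cyclohexyl in place of hydrogen on a saturated chain carbon. Within the data shown here, the one measured step that bears on this is a 1.7-fold lower number from compound 1 to compound 2 (0.23 log units; within the scatter), where cyclopentyl replaces ethyl. On that evidence, the expected step in this assay is of similar size and leans toward a lower number, without clearly passing the scatter: a 1.9-fold lower number from compound 1 to compound 3 (0.28 log units; within the scatter). For compound 3, the estimated value is 9 ug/mL, with an expected range of 3.5 ug/mL to 22 ug/mL.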

Compound 3, half-maximal cytotoxic concentration: 8.9 ug/mL
Compound 3: the middle estimate sits 1.0-fold (0.00 log units) above what was measured; measured number inside the range.
By their numbers in this assay, from the lowest: compounds 3, 2 and 1 (each within the scatter of the next).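

In this assay, cyclohexyl in place of hydrogen on a saturated chain carbon bound to a nitrogen on an aromatic ring and a saturated chain carbon gives a 1.9-fold lower number from compound 1 to compound 3 (0.28 log units; within the scatter). This position therefore takes cyclohexyl without a change that clears the scatter, so this larger addition to the chain shows no clear shift in the tolerated concentration. Nothing shown here gives a reason for this result. From the compounds shown here alone, it remains open whether an amine or a carboxylic acid at this chain carbon would also stay within the scatter. Going by these compounds, the opposite arrangement at this carbon also remains open.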